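Methoxyphenyl positional change on the cinnamamide series

This account rests on a few compounds, and the source may have more. Where it says the series, first, only, none or still open, it means among the compounds named here.

Compound 1 `COc1ccc(/C=C/C(=O)Nc2cc(C(=O)c3cc(OC)c(OC)c(OC)c3)ccc2OC)cc1` gives 12800 nM in a functional assay on DU-145 cells (Homo sapiens) for cytotoxicity, read by MTT assay, with a stated time of 72 h; on this read-out higher numbers stand for weaker inhibition and lower numbers for stronger inhibition. Compound 2 `COc1cccc(/C=C/C(=O)Nc2cc(C(=O)c3cc(OC)c(OC)c(OC)c3)ccc2OC)c1` differs by 3-methoxyphenyl in place of 4-methoxyphenyl on a double-bonded chain carbon bound to a double-bonded chain carbon and gives 6200 nM; the step is a 2.1-fold lower number from compound 1 to compound 2 (0.31 log units; beyond the scatter). Compound 3 `COc1ccc(/C=C/C(=O)Nc2cc(C(=O)c3cc(OC)c(OC)c(OC)c3)cc(OC)c2OC)cc1` carries a different core, differing from compound 1 by methoxy in place of hydrogen on an aromatic carbon; in this assay compound 3 gives 10400 nM, a step of a 1.2-fold lower number from compound 1 to compound 3 (0.09 log units; within the scatter).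

Compound 4 `COc1cccc(/C=C/C(=O)Nc2cc(C(=O)c3cc(OC)c(OC)c(OC)c3)cc(OC)c2OC)c1` is not yet measured. It differs from compound 3 by 3-methoxyphenyl in place of 4-methoxyphenyl on a double-bonded chain carbon bound to a double-bonded chain carbon, the same change as from compound 1 to compound 2, at the same place. Going by the values given here, only one example of that change is known here, so the expectation rests on a single step. Compound 4 is expected to show a step of a 2.1-fold lower number from compound 3 to compound 4 (0.32 log units; beyond the scatter), mirroring the step of a 2.1-fold lower number from compound 1 to compound 2 (0.31 log units; beyond the scatter). The estimate for compound 4 in this assay is 5000 nM, between 2500 nM and 10400 nM.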

Compound 4, half-maximal inhibitory concentration: 12500 nM
Beside the measured number, compound 4's estimate is 2.5-fold (0.40 log units) below it, outside the stated range (above it).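

In this assay, the change from 4-methoxyphenyl to 3-methoxyphenyl on the core of compound 3 gives a 1.2-fold higher number from compound 3 to compound 4 (0.08 log units; within the scatter), while the same change on the core of compound 1 lay beyond the scatter, yet the two steps cannot be told apart: the same change on two cores in this assay, a 2.1-fold lower number (0.31 log units; beyond the scatter) from compound 1 to compound 2 and a 1.2-fold higher number (0.08 log units; within the scatter) from compound 3 to compound 4, 2.5-fold (0.39 log units) apart, within the scatter of two such steps. The added methoxy, read on the 3-methoxyphenyl pair, gives a 2.0-fold higher number from compound 2 to compound 4 (0.30 log units; within the scatter), and this step also cannot be told apart from its earlier counterpart: the same change on two cores in this assay, a 1.2-fold lower number (0.09 log units; within the scatter) from compound 1 to compound 3 and a 2.0-fold higher number (0.30 log units; within the scatter) from compound 2 to compound 4, 2.5-fold (0.39 log units) apart, within the scatter of two such steps. With one pair per core, these results neither show that the change carries from one core to the other nor show that its outcome depends on the core.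

Open, on these data alone, is whether an amine or fluorine in place of the methoxy on that ring would separate the two cores. Also open, as far as these compounds go, is what a longer chain in place of the ethenyl link would do.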